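Swapping the cyclopropylmethyl arm for a nitrogen-bearing ring

The source may report more compounds than this note shows. Statements on the series, on what has been measured and on what is new or still open speak of the compounds shown alone.

Three compounds sharing one core differ only in the group attached to an oxygen on the aromatic ring. In an assay for inhibition of kynurenine 3-monooxygenase (Homo sapiens), read by mass spectrometry, with a stated time of 1 h (on this read-out higher numbers stand for weaker inhibition and lower numbers for stronger inhibition), compound 1 `O=C(O)CCn1c(=O)oc2cc(OCc3ccccc3)c(Cl)cc21` gives 25.1 nM. Compound 2 `O=C(O)CCn1c(=O)oc2cc(OCc3ccccn3)c(Cl)cc21` gives 3.16 nM, and compound 3 `O=C(O)CCn1c(=O)oc2cc(OCC3CC3)c(Cl)cc21` gives 10 nM. Compound 3 stands second highest of the three numbers: one step is a 2.5-fold lower number from compound 1 to compound 3 (0.40 log units; beyond the scatter), and the other is a 3.2-fold higher number from compound 2 to compound 3 (0.50 log units; beyond the scatter). The change to compound 4 `C[C@@H](Oc1cc2oc(=O)n(CCC(=O)O)c2cc1Cl)c1ncccn1` is a group of 8 heavy atoms (6 carbon, 2 nitrogen; one six-membered aromatic ring with 2 hetero atoms) in place of a group of 4 heavy atoms (4 carbon; one three-membered non-aromatic ring of carbon only), on an oxygen on an aromatic ring. The most relevant measured steps are a 7.9-fold lower number from compound 1 to compound 2 (0.90 log units; beyond the scatter) and a 3.2-fold higher number from compound 2 to compound 3 (0.50 log units; beyond the scatter), both pointing to a lower number when a six-membered aromatic ring with nitrogen sits on that chain carbon rather than phenyl or cyclopropyl. For the measured compounds named here, a modest step downward is therefore expected here, with extra uncertainty from the added stereocentre, which no measured compound carries. Compound 4 is expected to give 3.5 nM, within 0.8 nM to 15 nM, a step of a 2.9-fold lower number from compound 3 to compound 4 (0.46 log units; beyond the scatter).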

Compound 4, half-maximal inhibitory concentration: 5.01 nM
For compound 4 the middle estimate is 1.4-fold (0.16 log units) below the measured one; low and high end bracket the measured number.
By their numbers in this assay, from the lowest: compounds 2, 4 and 3 (each within the scatter of the next, the first and the last beyond it); then compound 1.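

In this assay, this place on an oxygen on an aromatic ring tolerates the group of compound 4, with its six-membered aromatic ring with 2 hetero atoms and its defined stereocentre, and the number stays clearly apart from that of the phenyl compound, with a 5.0-fold lower number from compound 1 to compound 4 (0.70 log units; beyond the scatter). Against the other two compounds the new group shows no real difference: a 2.0-fold lower number from compound 3 to compound 4 (0.30 log units; within the scatter) and a 1.6-fold higher number from compound 2 to compound 4 (0.20 log units; within the scatter) both lie within the scatter. The larger group therefore brings no measurable gain over cyclopropylmethyl or the pyridin-2-yl group.

As far as these compounds go, the stereocentre and the second ring hetero atom enter together, so their separate shares stay open, as does what an amine or a longer chain on that oxygen would give. No measurement shown offers any explanation for these numbers.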